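The source may hold more compounds than are shown below. What is called first, only, known or untested is meant among the compounds shown, and "the series" means these compounds.

Measured so far in a functional assay on the whole organism (strain Hartley) for inhibition, with Cavia porcellus as the target, with stated times of 15 min and 2 min; on this read-out higher numbers stand for an effect only at larger amounts of compound and lower numbers for an effect already at smaller amounts

Compound 1 `CCCCC1([C@H](O)/C=C/C2CCC(=O)[C@@H]2CCCCCC(=O)O)CCC1` gives 0.032 mg/kg
Compound 2 `CCCCC1([C@H](O)/C=C/C2CCC(=O)[C@@H]2CCCCCCC(=O)OCC)CCC1` gives 0.409 mg/kg

Of the two numbers, compound 2 holds the higher one, and its gap to compound 1 lies beyond the scatter. Next comes compound 3 `CCCCC1([C@H](O)/C=C/C2CCC(=O)[C@@H]2CCCCCCCCC(=O)OCC)CCC1` and its difference from compound 2 is 2-(ethoxycarbonyl)ethyl in place of ethoxycarbonyl on a saturated chain carbon, six bonds along the chain from a saturated ring carbon so the ester stays and the chain grows. For the measured compounds named here, only one measured step bears on this. The step of a 13-fold higher number from compound 1 to compound 2 (1.11 log units; beyond the scatter) is large, but it puts (ethoxycarbonyl)methyl in place of carboxy, so ester formation and chain growth come together in it. Going by the values given here, no measured step shows chain growth alone. A small move towards a higher number is therefore expected in this assay and it may stay within the scatter. The expected step is a 1.7-fold higher number from compound 2 to compound 3 (0.23 log units; within the scatter) as an estimate only. For compound 3 the estimate is 0.7 mg/kg with an expected range from 0.15 mg/kg to 3 mg/kg on this read-out.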

Compound 3, dose for half-maximal effect: 4.38 mg/kg
Compound 3: middle estimate off by 6.3-fold (0.80 log units), on the low side; the measured number lies above the stated range.
By their numbers in this assay, from the lowest: compound 1; then compound 2; then compound 3.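

Chain growth with the ethyl ester kept can now be read on its own: in this assay, 2-(ethoxycarbonyl)ethyl in place of ethoxycarbonyl on a saturated chain carbon, six bonds along the chain from a saturated ring carbon, gives an 11-fold higher number from compound 2 to compound 3 (1.03 log units; beyond the scatter). This step is large, as is a 13-fold higher number from compound 1 to compound 2 (1.11 log units; beyond the scatter), so among the esters shown chain length at this position is not neutral, and the combined change reaches a 140-fold higher number from compound 1 to compound 3 (2.14 log units; beyond the scatter). Nothing at hand accounts for the rise.

Open, as far as these compounds go, is how a carboxylic acid at the end of the longer chain of compound 3 would read, as the acid appears here only on the shortest chain. Also open, from the compounds shown here alone, is how a primary amide in place of the ethyl ester would read at either chain length.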